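Replacing piperidin-1-yl with acetamido on compound 2

A few compounds are considered here, and "the series" means these few. Any claim that something is new, unique, unknown or untested is made for them only; others in the source may bear on it.

In a functional assay on DU-145 cells (Homo sapiens) for cytotoxicity, read by MTT assay, with a stated time of 72 h (on this read-out lower numbers stand for stronger inhibition and higher numbers for weaker inhibition), compound 1 `O=c1ccc2nc(-c3ccccc3)nn(-c3ccccc3)c-2c1` gives 230 nM and compound 2 `O=c1cc2n(-c3ccccc3)nc(-c3ccccc3)nc-2cc1N1CCCCC1` gives 610 nM, the higher of the two numbers. Compound 3 `CC(=O)Nc1cc2nc(-c3ccccc3)nn(-c3ccccc3)c-2cc1=O` has acetamido in place of piperidin-1-yl on an aromatic carbon. Among the measured compounds shown here, the only measured guide is a 2.7-fold higher number from compound 1 to compound 2 (0.42 log units; beyond the scatter), a modest step on adding piperidin-1-yl at that carbon, and no acetamido compound has been measured. In this assay, the expected change is therefore small, an estimated 1.5-fold lower number from compound 2 to compound 3 (0.18 log units; within the scatter). For compound 3 the estimate is 400 nM, with an expected range of 130 nM to 1200 nM.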

Compound 3, half-maximal inhibitory concentration: > 5000 nM
Compound 3 gave a limit, no number; the forecaster's own chance of this, stated with the estimate: 3%; at least 12-fold (1.09 log units) between middle value and limit.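

In this assay compound 3 gives only a limit of the assay, not a number: the limit of > 5000 nM in this assay, at which 1 of the 3 values shown sits. Acetamido at this aromatic carbon gives an at least 8.1-fold higher number from compound 2 to compound 3 (0.91 log units; beyond the scatter), and against the unsubstituted core it gives an at least 21-fold higher number from compound 1 to compound 3 (1.33 log units; beyond the scatter). So the outcome here depends on which group enters, not just on whether the carbon carries one, and having fewer heavy atoms than piperidin-1-yl did not keep the number low.

Still open, on these data alone, is which part of acetamido matters: the amide hydrogen, the carbonyl or the absence of a ring. A simple dimethylamino group or a morpholin-4-yl ring at this carbon would help separate these.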